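Adding a second chloro to compound 1

The source may hold more compounds than are shown below. What is called first, only, known or untested is meant among the compounds shown, and "the series" means these compounds.

Values in a functional assay on MDA-MB-231 cells (Homo sapiens) for antiproliferative activity, read by MTT assay, with a stated time of 72 h; a lower number here means a stronger inhibitor, a higher number a weaker inhibitor:
Compound 1 `COc1cc(CCc2ccccc2Cl)cc(OC)c1O`: 21100 nM
Compound 2 `COc1cc(CCc2ccccc2F)cc(OC)c1O`: 9220 nM

Compound 1 has the higher of the two numbers, so it is the weaker inhibitor of the pair. Compound 3 `COc1cc(CCc2cccc(Cl)c2Cl)cc(OC)c1O` differs from it by chloro in place of hydrogen on an aromatic carbon, with the new chloro ortho to a chloro group and meta to a large group. For the measured compounds named here, the one measured step, a 2.3-fold lower number from compound 1 to compound 2 (0.36 log units; beyond the scatter), is modest and exchanges one halogen for another rather than adding a group, so it offers only loose guidance. A small step towards a higher number is therefore expected, perhaps none beyond the scatter. Compound 3 is expected at 24000 nM, with an estimated range of 9000 nM to 60000 nM. This estimate means an expected 1.1-fold higher number from compound 1 to compound 3 (0.06 log units; within the scatter).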

Compound 3, half-maximal inhibitory concentration: 6870 nM
The estimate for compound 3 lay 3.5-fold (0.54 log units) above the measured number; measured number outside the range, below it.
By their numbers in this assay, from the lowest: compounds 3 and 2 (each within the scatter of the next); then compound 1.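

Chloro in place of hydrogen at this position, ortho to the chloro group of compound 1, gives a 3.1-fold lower number from compound 1 to compound 3 (0.49 log units; beyond the scatter) in this assay, so the added group brings a modest gain rather than a loss. The earlier step only exchanged one halogen for another, whereas this one shows that the position can take an added chloro. Nothing available explains this gain. As far as these compounds go, whether a methyl or methoxy group at this position would give a similar step remains open. So does whether this chloro would have the same effect without the neighbouring chloro group.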